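Moving the trifluoromethyl group around the aryl ring

The source may hold more compounds than are shown below. What is called first, only, known or untested is meant among the compounds shown, and "the series" means these compounds.

Compound 1 `CCCc1nc(-c2ccccc2)c(CNCCN2CCN(c3cccc(C(F)(F)F)c3)CC2)o1` is the stronger of the two measured compounds in an assay on HEK293 cells for inhibition of Voltage-dependent T-type calcium channel subunit alpha-1G (Homo sapiens), read by patch clamp (on this read-out higher numbers stand for weaker inhibition and lower numbers for stronger inhibition), where compound 1 gives 1940 nM. Compound 2 `CCCc1nc(-c2ccccc2)c(CNCCCN2CCN(c3ccc(C(F)(F)F)cc3)CC2)o1` carries a longer chain and a differently placed trifluoromethyl group, and in this assay compound 2 gives 7250 nM. Compound 3 `CCCc1nc(-c2ccccc2)c(CNCCN2CCN(c3ccc(C(F)(F)F)cc3)CC2)o1` differs from compound 1 in one respect: 4-(trifluoromethyl)phenyl in place of 3-(trifluoromethyl)phenyl on an amine nitrogen in a ring. For the measured compounds named here, no single step isolates this change among the measured pair. A modest weakening is expected, since compound 2 gives 7250 nM with the same aryl group. For compound 3 the expected step is a 1.8-fold higher number from compound 1 to compound 3 (0.26 log units; within the scatter), giving an estimated 3500 nM with a range from 1200 nM to 10000 nM.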

Compound 3, half-maximal inhibitory concentration: 1300 nM
The estimate for compound 3 lay 2.7-fold (0.43 log units) above the measured number; the range from low to high includes it.
By their numbers in this assay, from the lowest: compounds 3 and 1 (each within the scatter of the next); then compound 2.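

In this assay the change to 4-(trifluoromethyl)phenyl gives a 1.5-fold lower number from compound 1 to compound 3 (0.17 log units; within the scatter) and so separates the two placements by no more than the usual scatter. With this same aryl group compound 2 gives 7250 nM and compound 3 gives 1300 nM on the shorter chain, so the aryl group alone does not account for the higher number of compound 2. Nothing available explains why the two placements read alike.

The compounds shown leave open how an unsubstituted phenyl group would read at this position. They also leave open the effect of a methoxy group or a nitrile in place of the trifluoromethyl group.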